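The source may hold more compounds than are shown below. What is called first, only, known or untested is meant among the compounds shown, and "the series" means these compounds.

Among the measured compounds shown here, compound 2 `COc1ccc2c(=O)c(/C=C/C(=O)Nc3cc(C)ccc3C)coc2c1` is one of two compounds measured in an ADME assay on HepG2 2.2.15 cells (Homo sapiens) for cytotoxicity, read by MTT assay, with stated times of 48 h and 9 days; on this read-out lower numbers stand for higher toxicity in this test and higher numbers for lower toxicity in this test. In this assay compound 2 gives 1100000 nM, the higher of the two numbers, while compound 1 `COc1ccc2c(=O)c(/C=C/C(=O)Nc3ccccc3Cl)coc2c1` gives 1010000 nM. For the measured compounds named here, the one comparison available, a 1.1-fold higher number from compound 1 to compound 2 (0.04 log units; within the scatter), is a change of the group on the amide-type nitrogen that leaves the read-out unchanged within the scatter.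

Compound 3 `COc1ccc(CNC(=O)/C=C/c2coc3cc(OC)ccc3c2=O)cc1` is the next compound in line. It differs from compound 2 by 4-methoxybenzyl in place of 2,5-dimethylphenyl on an amide-type nitrogen. Going by the values given here, the only measured step bearing on this position is the one from compound 1 to compound 2, and it was flat, so a step from compound 2 to compound 3 of no more than the scatter is expected, that is a 1.1-fold lower number from compound 2 to compound 3 (0.04 log units; within the scatter). On that basis compound 3 is estimated to give 1000000 nM in this assay, with a range from 400000 nM to 2500000 nM.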

Compound 3, half-maximal cytotoxic concentration: 43000 nM
Compound 3: middle estimate off by 23-fold (1.37 log units), on the high side; measured number outside the range, below it.
By their numbers in this assay, from the lowest: compound 3; then compounds 1 and 2 (each within the scatter of the next).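

With a 26-fold lower number from compound 2 to compound 3 (1.41 log units; beyond the scatter) and a 23-fold lower number from compound 1 to compound 3 (1.37 log units; beyond the scatter) in this assay, the group on the amide-type nitrogen proves able to move the read-out a long way, which the flat exchange of 2-chlorophenyl and 2,5-dimethylphenyl did not reveal. The 4-methoxybenzyl group differs from both of those phenyl groups in two ways at once, as a benzyl group and as a carrier of a methoxy group, so these steps cannot separate the two changes. Nothing at hand accounts for the lower number.

The compounds shown leave open whether an unsubstituted benzyl group, or a 4-methoxyphenyl group placed directly on the nitrogen, would go with the higher or the lower numbers. They also leave open how a longer chain between the nitrogen and the ring, or an amine or carboxylic acid on that ring, would read in this test.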